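The compounds below may be only part of what the source reports. "The series", "measured", "known", "first", "only" and "open" are said of these compounds alone.

Measured compounds:
- compound 1, `CC(C)C[C@H](N)CN(C(=O)C(C)Cc1ccccc1)c1ccc(-c2ccccc2)cc1`: 1.2 nM
- compound 2, `CC[C@H](C)[C@H](N)CN(C(=O)[C@@H]1C[C@H]1c1nccs1)c1ccc(-c2ccccc2)cc1`: 210 nM
- compound 3, `CC(C)C[C@H](N)CN(C(=O)[C@@H]1C[C@H]1c1ccccc1)c1ccc(-c2ccoc2)cc1`: 2000 nM

In a functional assay for agonist activity at G protein-coupled receptor 88 (Homo sapiens), read by HTRF and cAMP accumulation (on this read-out higher numbers stand for an effect only at larger amounts of compound and lower numbers for an effect already at smaller amounts), compound 3 gives 2000 nM, the highest of the three numbers. Its nearest neighbour is compound 2, which in this assay gives 210 nM, a gap beyond the scatter; the furthest is compound 1, which gives 1.2 nM, a far larger gap.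

Compound 4, `CC(C)C[C@H](N)CN(C(=O)[C@@H]1C[C@H]1c1ccccc1)c1ccc(-c2ccccc2Cl)cc1`, differs from compound 3 in one place: 2-chlorophenyl in place of furan-3-yl on an aromatic carbon. Going by the values given here, both compound 1 and compound 2 carry a six-membered aromatic ring of carbon only at the corresponding place, and both stand well below compound 3; yet they also differ from compound 3 elsewhere, so no clean step for the ring exchange alone exists. Taking the two lower values as a rough guide, the step from compound 3 to compound 4 is expected to be downward and beyond the scatter, a 13-fold lower number from compound 3 to compound 4 (1.12 log units; beyond the scatter), though its exact size is uncertain. Compound 4 is therefore estimated at 150 nM in this assay, within a range from 20 nM to 1000 nM.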

Compound 4, half-maximal effective concentration: 3800 nM
Compound 4: the middle estimate sits 25-fold (1.40 log units) below what was measured, outside the stated range (above it).
By their numbers in this assay, from the lowest: compound 1; then compound 2; then compounds 3 and 4 (each within the scatter of the next).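

In this assay, putting 2-chlorophenyl in place of furan-3-yl gives a 1.9-fold higher number from compound 3 to compound 4 (0.28 log units; within the scatter) and so the two compounds cannot be told apart: at this place, on an aromatic carbon para to a large group, the two groups read alike. With the phenylcyclopropane amide of compound 3 and compound 4 held constant, a six-membered aromatic ring of carbon only that carries chlorine does not separate from a five-membered aromatic ring with one hetero atom, and giving up the hydrogen-bond acceptor of furan-3-yl leaves no step beyond the scatter. No measurement at hand gives a reason for this likeness.

Compound 1 and compound 2 each differ from compound 4 in more than one place, so what sets their numbers apart cannot be assigned to this ring or to the amide part. Still open, going by these compounds, is how a plain phenyl ring would read at this place with this amide, and whether a methoxy group or a nitrile on that ring, or a pyridine ring in its stead, would read differently from 2-chlorophenyl.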